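The source may report more compounds than this note shows. Statements on the series, on what has been measured and on what is new or still open speak of the compounds shown alone.

Of the compounds shown here, three have been measured in an ADME assay on Caco-2 cells (Homo sapiens) for permeability, in the apical to basolateral direction; on this read-out higher numbers stand for higher permeability and lower numbers for lower permeability. Compound 1 `Cn1cncc1CN1CC(N(CCn2cccc2)S(=O)(=O)c2ccccn2)Cc2cc(C#N)ccc21` gives 12.4 10^-6 cm/s, compound 3 `Cc1noc(C)c1CN(C1Cc2cc(C#N)ccc2N(Cc2cncn2C)C1)S(=O)(=O)c1ccccn1` gives 8 10^-6 cm/s, and compound 2 `Cn1cnc(S(=O)(=O)N2CCC(CN(C3Cc4cc(C#N)ccc4N(Cc4cncn4C)C3)S(=O)(=O)c3ccccn3)CC2)c1` gives 0.1 10^-6 cm/s. Compound 3 thus stands second highest of the three: its gap to compound 1 is within the scatter, while compound 2 lies far below it. Among the compounds with values here, the one measured step, a 1.6-fold lower number from compound 1 to compound 3 (0.19 log units; within the scatter), swapped a different group and tells little about the change now considered. Compound 4 `CCS(=O)(=O)N1CCC(CN(C2Cc3cc(C#N)ccc3N(Cc3cncn3C)C2)S(=O)(=O)c2ccccn2)CC1` differs from compound 3 in one place: 1-(ethylsulfonyl)piperidin-4-yl in place of 3,5-dimethyl-1,2-oxazol-4-yl on a saturated chain carbon bound to a sulfonamide nitrogen. Compound 2 already carries a sulfonyl-bearing piperidinyl group at the same place and sits far lower, so a large drop is expected, a 13-fold lower number from compound 3 to compound 4 (1.12 log units; beyond the scatter). Compound 4 is therefore estimated at 0.6 10^-6 cm/s, between 0.1 10^-6 cm/s and 3 10^-6 cm/s.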

Compound 4, apparent permeability: 0.1 10^-6 cm/s
Beside the measured number, compound 4's estimate is 6.0-fold (0.78 log units) above it, and the stated range covers the measured number.
By their numbers in this assay, from the lowest: compounds 2 and 4 (each within the scatter of the next); then compounds 3 and 1 (each within the scatter of the next).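

In this assay, 1-(ethylsulfonyl)piperidin-4-yl on a saturated chain carbon bound to a sulfonamide nitrogen brings a large fall (an 80-fold lower number from compound 3 to compound 4 (1.90 log units; beyond the scatter)), and the gap to the pyrrole-bearing compound is as large (a 120-fold lower number from compound 1 to compound 4 (2.09 log units; beyond the scatter)). What sits on the sulfonyl sulfur counts for little here, as ethyl in place of 1-methyl-1H-imidazol-4-yl gives no visible shift (no change at the digits printed from compound 2 to compound 4 (within the scatter)). Both compounds with a sulfonyl-bearing piperidine therefore sit low, whichever of these two groups it carries. On these data alone, whether a piperidine with a plain amine nitrogen, lacking the sulfonyl group, would sit as low remains open. Nothing measured here says why the number falls so far.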